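The compounds below may be only part of what the source reports. "The series", "measured", "known", "first", "only" and "open" are said of these compounds alone.

Of the compounds shown here, three built on one shared core have been measured in an assay for positive allosteric modulation of metabotropic glutamate receptor 2 (Rattus norvegicus); a lower number here means that less compound is needed, a higher number that more compound is needed for the effect. Compound 1 `Cc1c(OC[C@H](C)COc2ccc(F)c(C(=O)O)c2)ccc(C(=O)CC(C)(C)C)c1O` gives 294 nM. Compound 2 `Cc1c(OC[C@@H](C)COc2ccc(F)c(C(=O)O)c2)ccc(C(=O)CC(C)(C)C)c1O` gives 112 nM. Compound 3 `COc1ccc(C(=O)O)cc1OC[C@H](C)COc1ccc(C(=O)CC(C)(C)C)c(O)c1C` gives 63 nM. Compound 2 thus stands second highest of the three numbers: its gap to compound 3 lies within the usual scatter, while a 2.6-fold lower number from compound 1 to compound 2 (0.42 log units; beyond the scatter) is a modest step beyond the scatter. Because (the fact that compounds 1 and 2 differ only in the configuration as drawn), that step reflects configuration alone, and the configuration at the saturated chain carbon of compound 2 is kept in compound 4 `Cc1c(OC[C@@H](C)COc2ccc(C(=O)O)cc2Cl)ccc(C(=O)CC(C)(C)C)c1O`. Compound 4 differs from compound 2 in the aromatic group on an oxygen on a saturated carbon: 4-carboxy-2-chlorophenyl in place of 3-carboxy-4-fluorophenyl on an oxygen on a saturated carbon. For the measured compounds named here, no measured pair changes that group by itself; the single measured step concerns configuration and says nothing about swapping one substituted phenyl for another. Compound 3 carries yet another substitution pattern on that ring and its number sits within the scatter of compound 2, a single hint that this part of the molecule may accept variation, though one comparison is thin ground. The expectation for compound 4 is therefore a step of a 1.3-fold higher number from compound 2 to compound 4 (0.13 log units; within the scatter), within the scatter in either direction. Compound 4 is estimated at 150 nM, with a range from 50 nM to 450 nM.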

Compound 4, half-maximal effective concentration: 477 nM
Compound 4: the middle estimate sits 3.2-fold (0.50 log units) below what was measured; the whole stated range lies below it.
By their numbers in this assay, from the lowest: compounds 3 and 2 (each within the scatter of the next); then compounds 1 and 4 (each within the scatter of the next).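

In this assay, the aromatic group on an oxygen on a saturated carbon turns out not to be a place where substitution can be changed freely: a 4.3-fold higher number from compound 2 to compound 4 (0.63 log units; beyond the scatter), while the configuration at the saturated chain carbon stays the same. For the compounds shown here, this is the first measured step at this position, and it shows that replacing 3-carboxy-4-fluorophenyl with 4-carboxy-2-chlorophenyl, two groups with equal heavy-atom counts, can move the number beyond the scatter, so the single earlier hint of tolerance does not hold for every substitution pattern on this ring. The swap alters the halogen and the arrangement of the groups on the ring together, and nothing in the available data accounts for the size of this step.

The compounds shown leave open whether the higher number goes with the chlorine or with the new arrangement of the carboxylic acid and halogen, a question that a single pair cannot settle. They also leave open how the number would respond to a ring carrying a primary amide or a nitrile in place of the carboxylic acid, or a bromine in place of the chlorine.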